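The compounds below may be only part of what the source reports. "The series", "measured", "known", "first", "only" and "open" are said of these compounds alone.

Series notes. Of the compounds shown here, three have numbers so far. Compound 1 `CC[C@@H]1C(=O)N(C)c2cnc(-n3ccc4cc(C(N)=O)ccc43)nc2N1C1CCCC1` gives 28.5 nM in an assay for inhibition of serine/threonine-protein kinase PLK2 (Homo sapiens), read by FRET and Z'-LYTE, with a stated time of 1 h; on this read-out higher numbers stand for weaker inhibition and lower numbers for stronger inhibition. Compound 2 `CCC1C(=O)N(C)c2cnc(-n3ccc4cc(C(=O)NC(C)C)ccc43)nc2N1c1ccn(C)n1` gives 125 nM in this assay. Compound 3 `CCCNS(=O)(=O)c1ccc(Nc2ncc3c(n2)N(C2CCCC2)[C@H](CC)C(=O)N3C)cc1` gives 17.8 nM in this assay. On these numbers compound 3 stands lowest of the three: compound 1 sits within the scatter of it, so no order between those two can be read, while compound 2 sits beyond the scatter and is the weaker of the pair. No two of these compounds differ in a single place, so no counted step between measured compounds exists.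

Compound 4 `CC[C@@H]1C(=O)N(C)c2cnc(Nc3ccc(S(N)(=O)=O)cc3)nc2N1C1CCCC1` is the next one to be measured and differs from compound 3 in one place only: hydrogen in place of propyl on a sulfonamide nitrogen. Nothing measured in the series bears on this change, so the expectation rests on compound 3 alone and on the change being confined to a sulfonamide nitrogen. The step from compound 3 to compound 4 is expected to be a 1.4-fold higher number from compound 3 to compound 4 (0.15 log units; within the scatter), which is not beyond the scatter. Compound 4 is accordingly estimated at 25 nM, with a range from 8 nM to 80 nM.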

Compound 4, half-maximal inhibitory concentration: 10.2 nM
For compound 4 the middle estimate is 2.5-fold (0.39 log units) above the measured one; the measured number falls inside the stated range.
By their numbers in this assay, from the lowest: compounds 4, 3 and 1 (each within the scatter of the next, the first and the last beyond it); then compound 2.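

Within the data shown here, the first counted step comes at the sulfonamide nitrogen: in this assay, hydrogen in place of propyl gives a 1.7-fold lower number from compound 3 to compound 4 (0.24 log units; within the scatter), so the two compounds cannot be told apart. At this nitrogen, then, the propyl chain is not needed for a number of this size, and the unsubstituted sulfamoyl group serves as well as the propylsulfamoyl group within the scatter. Nothing at hand bears on why the two compounds read alike.

With only hydrogen and propyl at this place, the compounds shown leave open how a longer chain, a chain ending in an amine or one ending in a carboxylic acid would read. Also open, on these data alone, is whether two methyl groups on this nitrogen, which would leave it with no hydrogen, would read the same.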